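Compound 2 to Compound 3: a Second Hydroxymethyl

The compounds below may be only part of what the source reports. "The series", "measured", "known", "first", "only" and "open" are said of these compounds alone.

The study concerns cytotoxicity in an ADME assay on HL-60 cells (Homo sapiens) for cytotoxicity, read by luminescence and ATP content, with a stated time of 48 h; a lower number here means a stronger inhibitor, a higher number a weaker inhibitor. Compound 1, `COc1cc(OC)c(C2=C(c3ccc(OC)c(OC)c3OC)COC2=O)c(OC)c1`, was measured in this assay and gave only a limit of > 40000 nM. Compound 2, `COc1ccc(C2=C(c3ccc(OC)c(OC)c3)C(CO)OC2=O)cc1`, likewise gave only a limit of > 40000 nM in this assay. Compound 2 thus stands at the edge of the range shown, where both recorded values are limits rather than numbers, as summarized by the limit of > 40000 nM in this assay, at which 2 of the 2 values shown sit. Compound 3, `COc1ccc(C2=C(c3ccc(OC)c(OC)c3)C(CO)(CO)OC2=O)cc1`, has not yet been measured. It differs from compound 2 by hydroxymethyl in place of hydrogen on a saturated ring carbon. Among the compounds with values here, no step between measured compounds is available to gauge such a change. Because both measured values sit at the limit of > 40000 nM in this assay, at which 2 of the 2 values shown sit, the step from compound 2 to compound 3 is expected to be a number no higher from compound 2 to compound 3 (the limit leaves the size open), none beyond the scatter. Compound 3 is therefore estimated at 40000 nM, with an expected range from 15000 nM to 100000 nM, most likely again reported only as a limit.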

Compound 3, half-maximal inhibitory concentration: > 40000 nM
Compound 3: no number, only a limit; the forecaster's own chance of this, stated with the estimate: 85%; the middle value lies on the limit itself.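

In this assay compound 3 gives > 40000 nM, which is a limit and not a number. Compound 2 also has only a limit, so no step can be read between compound 2 and compound 3. The compounds shown leave open how strongly each one inhibits and whether the added hydroxymethyl makes any difference.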